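This account rests on a few compounds, and the source may have more. Where it says the series, first, only, none or still open, it means among the compounds named here.

Measured so far in an ADME assay on MRC5 cells (Homo sapiens) for inhibition, with a stated time of 72 h; a higher number here means that more compound is needed for the effect, a lower number that less compound is needed:
- compound 1 `CO[C@H]1CC[C@H](NC(=O)c2n[nH]cc2NC(=O)c2ccc(N3CCCC3)cc2)CC1` gives > 50000 nM, which is a limit of the assay rather than a number.
- compound 2 `COc1cccc(OC)c1C(=O)Nc1c[nH]nc1C(=O)NC1CCCCCC1` gives 42000 nM.
- compound 3 `CO[C@H]1CC[C@H](NC(=O)c2n[nH]cc2NC(=O)c2cc(F)cc(F)c2)CC1` gives 600 nM.

Of the two compounds that yielded a number in this assay, compound 2 stands at the highest, meaning the most compound is needed for the effect. Its nearest neighbour, compound 3, sits far lower, and that gap lies well beyond the usual scatter of repeated measurements. Compound 1 reaches only a limit: the limit of > 50000 nM in this assay, at which 1 of the 3 values shown sits.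

Compound 4 `COc1cccc(OC)c1C(=O)Nc1c[nH]nc1C(=O)NC1CC2CCC1C2` has not yet been measured. It differs from compound 2 in one place: a group of 7 heavy atoms (7 carbon; 2 five-membered non-aromatic rings of carbon only) in place of a group of 7 heavy atoms (7 carbon; one seven-membered non-aromatic ring of carbon only), on an amide-type nitrogen. One saturated carbon ring is exchanged for another, so the rest of the molecule is untouched.

Among the compounds with values here, no pair of measured compounds shows a change of this kind, so there is no measured guide for its size. The step from compound 2 to compound 4 in this assay is expected to be a 1.1-fold lower number from compound 2 to compound 4 (0.02 log units; within the scatter), that is, no change beyond the scatter, resting on the value of compound 2 at 42000 nM. For compound 4 the estimate in this assay is 40000 nM, with a range from 15000 nM to 100000 nM.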

Compound 4, half-maximal effective concentration: > 50000 nM
Compound 4 was reported as a limit (the forecaster's own chance of this, stated with the estimate: 40%); middle value at least 1.2-fold (0.09 log units) from the limit.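

In this assay compound 4 gives > 50000 nM, which is a limit of the assay and not a number. The step is an at least 1.1-fold higher number from compound 2 to compound 4 (0.07 log units; that floor lies within the scatter), so swapping cycloheptyl for the group with 2 five-membered non-aromatic rings of carbon only, on this amide-type nitrogen, does not bring the number down towards the much lower value of compound 3, although compound 3 differs from compound 2 in more than one place and cannot be used to explain this step. This limit now recurs among the compounds shown: the limit of > 50000 nM in this assay, at which 2 of the 4 values shown sit.

As far as these compounds go, how far the true value of compound 4 lies from that of compound 2 stays open, since only a floor can be read. Also open, from the compounds shown here alone, is whether an amine or a carboxylic acid on this nitrogen, rather than a ring of carbon only, would shift the number.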